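Compound 3 to compound 4: a change on the aryl group

The source may report more compounds than this note shows. Statements on the series, on what has been measured and on what is new or still open speak of the compounds shown alone.

- compound 1 `COc1cc(Nc2ncnc3c(NC(=O)Nc4ccc(C)cc4C)cccc23)cc(OC)c1`: 1290 nM
- compound 2 `COc1cc(Nc2ncnc3c(NC(=O)Nc4cccc(Cl)c4Cl)cccc23)cc(OC)c1`: 63.2 nM
- compound 3 `COc1cc(Nc2ncnc3c(NC(=O)Nc4cc(Cl)c(Cl)cc4Cl)cccc23)cc(OC)c1`: 4890 nM
- compound 4 `COc1cc(Nc2ncnc3c(NC(=O)Nc4ccc(Cl)c(C(F)(F)F)c4)cccc23)cc(OC)c1`: not yet measured

In a functional assay on RT-112 cells (Homo sapiens) for antiproliferative activity, read by MTT assay, with a stated time of 72 h (a higher number here means a weaker inhibitor of growth, a lower number a stronger inhibitor of growth), compound 3 has the highest number of the three, at 4890 nM. The next step is 4-chloro-3-(trifluoromethyl)phenyl in place of 2,4,5-trichlorophenyl on an amide-type nitrogen. In words, this places 4-chloro-3-(trifluoromethyl)phenyl in place of 2,4,5-trichlorophenyl on an amide-type nitrogen.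

All three measured steps involve this same place, and they vary widely: a 20-fold lower number from compound 1 to compound 2 (1.31 log units; beyond the scatter), a 3.8-fold higher number from compound 1 to compound 3 (0.58 log units; beyond the scatter) and a 77-fold higher number from compound 2 to compound 3 (1.89 log units; beyond the scatter). None of them contains the entering group, so none carries over directly. They show only that this position can move the number strongly in either direction. With compound 3 at the top of the measured range, any sizeable change is more likely to lead downward, toward the values of the other two compounds, than further up. The expected step, with wide uncertainty, is an 8.2-fold lower number from compound 3 to compound 4 (0.91 log units; beyond the scatter). Compound 4 is estimated at 600 nM, with an expected range of 90 nM to 3500 nM.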

Compound 4, concentration for 50% growth inhibition: > 20000 nM
Compound 4: no number, only a limit; the forecaster's own chance of this, stated with the estimate: 3%; at least 33-fold (1.52 log units) between middle value and limit.
By their numbers in this assay, from the lowest: compound 2; then compound 1; then compound 3. At a limit, above all of these: compound 4.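

Compound 4 gives no number in this assay, only a limit: (the limit of > 20000 nM in this assay, at which 1 of the 4 values shown sits). Placing 4-chloro-3-(trifluoromethyl)phenyl on the amide-type nitrogen raises the number whichever aryl group leaves: 2,4,5-trichlorophenyl (an at least 4.0-fold higher number from compound 3 to compound 4 (0.61 log units; beyond the scatter)), 2,3-dichlorophenyl (an at least 310-fold higher number from compound 2 to compound 4 (2.50 log units; beyond the scatter)) and 2,4-dimethylphenyl (an at least 15-fold higher number from compound 1 to compound 4 (1.19 log units; beyond the scatter)). Compound 3 therefore no longer marks the top of the series, and a change confined to the substituents of one aryl group is enough to reach the limit.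

Every pair shown differs in more than one substituent, which leaves open whether the trifluoromethyl group or the placing of the chlorines carries this rise. Also open, going by these compounds, is how this assay would read for an aryl group bearing an amine or a carboxylic acid at this position.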